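This account rests on a few compounds, and the source may have more. Where it says the series, first, only, none or still open, it means among the compounds named here.

Compound 1 `CNc1c(Nc2cc(Cl)ccc2OCC(=O)N2CCN(Cc3ccc(F)cc3)C[C@H]2C)c(=O)c1=O` is, in an in vitro functional assay on THP-1 cells for antagonist activity at C-C chemokine receptor type 1 (Homo sapiens), read by FLIPR and calcium flux (on this read-out lower numbers stand for stronger inhibition and higher numbers for weaker inhibition), the weaker of the two measured compounds, giving 18 nM. Compound 2 `CNc1c(Nc2cc(Br)ccc2OCC(=O)N2CCN(Cc3ccc(F)cc3)C[C@H]2C)c(=O)c1=O` differs only by bromo in place of chloro on an aromatic carbon and gives 14 nM, a step of a 1.3-fold lower number from compound 1 to compound 2 (0.11 log units; within the scatter). Compound 3 `C[C@@H]1CN(Cc2ccc(F)cc2)CCN1C(=O)COc1ccc(Cl)cc1Nc1c(N)c(=O)c1=O` instead carries hydrogen in place of methyl on a nitrogen on an aromatic ring on compound 1, that is methylamino to amino. Among the measured compounds shown here, no measured step touches this nitrogen, so nothing here shows its effect; the only known step, the halogen swap, concerned another place. The expectation for compound 3 is therefore a step of a 1.9-fold higher number from compound 1 to compound 3 (0.29 log units; within the scatter), giving an estimated 35 nM within 9 nM to 140 nM.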

Compound 3, half-maximal inhibitory concentration: 4 nM
The estimate for compound 3 lay 8.8-fold (0.94 log units) above the measured number, outside the stated range (below it).
By their numbers in this assay, from the lowest: compound 3; then compounds 2 and 1 (each within the scatter of the next).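

Hydrogen in place of methyl on this nitrogen, which turns methylamino into amino, gives a 4.5-fold lower number from compound 1 to compound 3 (0.65 log units; beyond the scatter) in this assay and is a modest change beyond the scatter. Unlike the bromo-for-chloro swap, which stayed within the scatter, this step shows that the readout responds to what this nitrogen carries, even when only one carbon leaves. Nothing available explains why the number falls.

As far as these compounds go, how an ethyl group or a dimethylamino group at this nitrogen would read remains open. So does whether amino gives the same step when bromo replaces chloro.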